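The source may report more compounds than this note shows. Statements on the series, on what has been measured and on what is new or still open speak of the compounds shown alone.

Compound 1 `COc1ccc([N+](=O)[O-])cc1CSc1nc2cc(NC(=O)NC(C)(C)C)ccc2n1C(C)C` and compound 2 `CNC(=O)Nc1ccc2c(c1)nc(SCc1cc([N+](=O)[O-])ccc1OC)n2C(C)C` share a core and differ only in tert-butyl in place of methyl on an amide-type nitrogen. In an assay on isolated protein for inhibition of Gonadotropin-releasing hormone receptor (Rattus norvegicus) (a higher number here means a weaker inhibitor, a lower number a stronger inhibitor), compound 1 gives 62 nM. For compound 2 the result is a limit, > 10000 nM. The step of an at least 160-fold lower number from compound 2 to compound 1 (2.20 log units; beyond the scatter) is known only as a lower bound because of the limit of > 10000 nM in this assay, at which 1 of the 3 values shown sits. Compound 3 `CCCn1c(SCc2cc([N+](=O)[O-])ccc2OC)nc2cc(NC(=O)NC(C)(C)C)cc(C(=O)NC)c21` has a core whose difference from compound 2 is not broken down here; in this assay compound 3 gives 23 nM. Compound 4 `CCCn1c(SCc2cc([N+](=O)[O-])ccc2OC)nc2cc(NC(=O)NC(C)(C)C)cc(C(=O)NC(C)(C)C)c21` differs from compound 3 by tert-butyl in place of methyl on an amide-type nitrogen, the same change as from compound 2 to compound 1, though the reading cut one bond further out lacks the (methylcarbamoyl)amino term. For compound 4 a smaller step is expected, a 1.3-fold higher number from compound 3 to compound 4 (0.12 log units; within the scatter). This rests on compound 3 already giving 23 nM. It rests also on the step from compound 2 to compound 1 being known only as a lower bound. Compound 4 is estimated at 30 nM, between 8 nM and 150 nM.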

Compound 4, half-maximal inhibitory concentration: 490 nM
Compound 4: the middle estimate sits 16-fold (1.21 log units) below what was measured, outside the stated range (above it).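

In this assay, tert-butyl in place of methyl on an amide-type nitrogen gives a 21-fold higher number from compound 3 to compound 4 (1.33 log units; beyond the scatter), the opposite direction to the earlier step, so the change does not carry over from one core to the other: the same change on two cores in this assay, an at least 160-fold lower number (2.20 log units; beyond the scatter) from compound 2 to compound 1 and a 21-fold higher number (1.33 log units; beyond the scatter) from compound 3 to compound 4, at least 3400-fold (3.53 log units) apart, beyond the scatter of two such steps

Compound 2 gives > 10000 nM, which is a limit and not a number.

With a single pair on each core, these results do not show why the direction reverses, nor how the change would behave on any further core.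

Open, as far as these compounds go, is how this assay responds when ethyl or isopropyl replaces the tert-butyl of the (tert-butyl)carbamoyl group of compound 4. Also open, from the compounds shown here alone, is the response to a carboxylic acid in place of that whole group.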